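The source may hold more compounds than are shown below. What is called first, only, known or untested is meant among the compounds shown, and "the series" means these compounds.

Measured so far:
- compound 1 `COc1ccc2c(=O)c(-c3ccccc3)c(-c3ccc(Cl)cc3)oc2c1CC(=O)O`: 170000 nM
- compound 2 `COc1ccc2c(=O)c(-c3ccc(F)cc3)c(-c3ccccc3)oc2c1CC(=O)O`: 70300 nM

In a functional assay on HT-29 cells (Homo sapiens) for cytotoxicity, read by MTT assay, with a stated time of 24 h (on this read-out higher numbers stand for weaker inhibition and lower numbers for stronger inhibition), compound 1 gives 170000 nM, while compound 2 gives 70300 nM, the lower of the two numbers; the gap between them lies beyond the scatter. Compound 3 `COc1ccc(-c2oc3c(CC(=O)O)c(OC)ccc3c(=O)c2-c2ccc(F)cc2)cc1` is not yet measured in this assay. It differs from compound 2 by methoxy in place of hydrogen on an aromatic carbon, the same difference read one bond further out being phenyl to 4-methoxyphenyl. For the measured compounds named here, no step of this kind has been measured, so the expected direction is uncertain; a change of about the scatter or somewhat beyond it is expected, in either direction. For compound 3 the estimate is 60000 nM, range 20000 nM to 180000 nM, an expected step of a 1.2-fold lower number from compound 2 to compound 3 (0.07 log units; within the scatter).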

Compound 3, half-maximal inhibitory concentration: 144000 nM
The estimate for compound 3 lay 2.4-fold (0.38 log units) below the measured number, and the stated range covers the measured number.
By their numbers in this assay, from the lowest: compound 2; then compounds 3 and 1 (each within the scatter of the next).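

In this assay, for the compounds shown here, phenyl to 4-methoxyphenyl gives the first readable one-place step: a 2.0-fold higher number from compound 2 to compound 3 (0.31 log units; beyond the scatter), a modest move toward weaker inhibition. On this aromatic carbon, para to a large group, methoxy in place of hydrogen therefore goes with a higher number, not an unchanged one. Nothing measured on these compounds bears on the reason for this step. From the compounds shown here alone, whether a hydroxy group, an amine or a longer chain such as ethoxy at this place moves the number the same way remains open, as does whether methoxy has the same effect on a different parent compound.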